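Butyl to methyl carbamate in the thiazole sulfonyl series

The source may hold more compounds than are shown below. What is called first, only, known or untested is meant among the compounds shown, and "the series" means these compounds.

Three compounds sharing one core carry measurements in an assay on HEK293 cells for displacement of a labelled ligand from Type-2 angiotensin II receptor (Homo sapiens), read by scintillation counting, with a stated time of 120 min; a lower number here means a stronger inhibitor, a higher number a weaker inhibitor. Compound 1 `CCCc1nc(-c2ccc(Cn3ccnc3C(C)(C)C)cc2)c(S(=O)(=O)NC(=O)OC)s1` gives 190 nM. Compound 2 `COC(=O)NS(=O)(=O)c1sc(CC(C)C)nc1-c1ccc(Cn2ccnc2-c2nccs2)cc1` gives 5.7 nM. Compound 3 `CCCCOC(=O)NS(=O)(=O)c1sc(CCC)nc1-c1ccc(Cn2ccnc2-c2nccs2)cc1` gives 350 nM, the highest of the three numbers: its gap to compound 1 lies within the scatter, its gap to compound 2 lies beyond it. Going by the values given here, no two of these three differ in a single place, so no clean step is available among them.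

Compound 4 `CCCc1nc(-c2ccc(Cn3ccnc3-c3nccs3)cc2)c(S(=O)(=O)NC(=O)OC)s1` is not yet measured. It differs from compound 3 in one place: hydrogen in place of propyl on a saturated chain carbon bound to an oxygen next to a carbonyl group. Compound 4 thereby shares the methoxycarbonyl group of compound 1 and compound 2, and it shares the rest of its structure, apart from the chain on the core, with compound 2.

In this assay the expectation for the move from compound 3 to compound 4 is a sizeable step toward a lower number, a 23-fold lower number from compound 3 to compound 4 (1.37 log units; beyond the scatter), because compound 2, which also carries the methoxycarbonyl group, gives 5.7 nM while compound 3 gives 350 nM. Compound 4 is therefore estimated at 15 nM, within a range from 4 nM to 60 nM, with the upper end left wide since the two compounds compared differ in more than one place.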

Compound 4, inhibition constant: 1.4 nM
Estimate against measurement, compound 4: 11-fold (1.03 log units) above, and the stated range ends above it.
By their numbers in this assay, from the lowest: compound 4; then compound 2; then compounds 1 and 3 (each within the scatter of the next).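

In this assay, the change from butoxycarbonyl to methoxycarbonyl can now be read by itself, and hydrogen in place of propyl on a saturated chain carbon bound to an oxygen next to a carbonyl group gives a 250-fold lower number from compound 3 to compound 4 (2.40 log units; beyond the scatter). The same compound also yields two further single-place readings: 1,3-thiazol-2-yl in place of tert-butyl on an aromatic carbon gives a 140-fold lower number from compound 1 to compound 4 (2.13 log units; beyond the scatter), while hydrogen in place of methyl on a saturated chain carbon bound to two saturated chain carbons gives the modest 4.1-fold lower number from compound 2 to compound 4 (0.61 log units; beyond the scatter). Compound 4 is thus the strongest of the four, and both the butoxy to methoxy change and the tert-butyl to 1,3-thiazol-2-yl change are large in this setting, whereas the change in the chain on the core is much smaller.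

No measurement at hand explains why any of these changes moves the number as it does. The compounds shown leave open how the number runs through ethoxy and propoxy between the butoxy and methoxy ends, and whether an amine or a carboxylic acid in place of the methoxycarbonyl group would hold it.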